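The source may report more compounds than this note shows. Statements on the series, on what has been measured and on what is new or still open speak of the compounds shown alone.

Measured so far in an ADME assay on MDBK cells (Bos taurus) for cytotoxicity, read by MTT assay, with a stated time of 96 h; on this read-out lower numbers stand for higher toxicity in this test and higher numbers for lower toxicity in this test:
- compound 1 (`FC(F)(F)c1cccc(NC(=S)Nc2ccc(Cl)cc2)c1`) gives 17000 nM
- compound 2 (`FC(F)(F)c1cccc(NC(=S)Nc2ccccc2)c1`) gives 49000 nM

Compound 2 holds the higher of the two numbers, at 49000 nM, and the next step leads to compound 3 (`CCNC(=S)Nc1cccc(C(F)(F)F)c1`). The change is ethyl in place of phenyl on an amide-type nitrogen, counted as ethyl in place of phenyl on an amide-type nitrogen. Among the measured compounds shown here, the only measured step touching that phenyl is a 2.9-fold higher number from compound 1 to compound 2 (0.46 log units; beyond the scatter), with hydrogen in place of chloro on an aromatic carbon. For the measured compounds named here, no measured step removes the whole ring, so this guide is loose. Following that single step, a modest further rise is expected, a 2.0-fold higher number from compound 2 to compound 3 (0.31 log units; beyond the scatter). Compound 3 is estimated at 100000 nM, with an expected range from 40000 nM to 250000 nM.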

Compound 3, half-maximal cytotoxic concentration: > 100000 nM
Compound 3: only a limit was reported (the forecaster's own chance of this, stated with the estimate: 25%); the middle value lies on the limit itself.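

For compound 3, this assay returns only a limit and not a number: the limit of > 100000 nM in this assay, at which 1 of the 3 values shown sits.
Ethyl in place of phenyl on the amide-type nitrogen gives an at least 2.0-fold higher number from compound 2 to compound 3 (0.30 log units; that floor lies within the scatter) and so cannot be told apart from the scatter on its floor alone.
Ethyl in place of 4-chlorophenyl gives an at least 5.8-fold higher number from compound 1 to compound 3 (0.76 log units; beyond the scatter) and shows that the whole ring, not only its chloro, can leave this position without the number falling.

On these data alone, how far the number of compound 3 lies past the limit remains open.
Also open, as far as these compounds go, is whether a longer chain such as butyl, an amine or a carboxylic acid on this nitrogen would hold the number at that limit.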